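Shortening the Chain After Three Epoxide Esters

This account rests on a few compounds, and the source may have more. Where it says the series, first, only, none or still open, it means among the compounds named here.

Three compounds sharing one core and differing only in the length of a straight chain have been measured in a functional assay for inhibition, with Rattus norvegicus as the target; on this read-out higher numbers stand for an effect only at larger amounts of compound and lower numbers for an effect already at smaller amounts. Compound 1 `CCCCCCC1(C(=O)OC)CO1` gives 20 uM. Compound 2 `CCCCCCCCCCCC1(C(=O)OC)CO1` gives 2.5 uM. Compound 3 `CCCCCCCCCCCCCCC1(C(=O)OC)CO1` gives 0.1 uM, the lowest of the three numbers. Each lengthening lowered the number: an 8.0-fold lower number from compound 1 to compound 2 (0.90 log units; beyond the scatter), and a 25-fold lower number from compound 2 to compound 3 (1.40 log units; beyond the scatter). Compound 4 `CCCCCCCCCCCCC1(C(=O)OC)CO1` differs from compound 3 by hydrogen in place of ethyl on a saturated chain carbon, ten or more bonds along the chain from a saturated ring carbon. This shortening runs against the direction of both measured steps, most directly the second, so the number is expected to rise, though by less than that step since only part of the added chain is removed. The expected change is a 6.0-fold higher number from compound 3 to compound 4 (0.78 log units; beyond the scatter). Compound 4 is therefore estimated at 0.6 uM in this assay, within a range of 0.15 uM to 2.5 uM.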

Compound 4, minimum effective concentration: 1 uM
Compound 4: middle estimate off by 1.7-fold (0.22 log units), on the low side, within the range that was stated.
By their numbers in this assay, from the lowest: compound 3; then compound 4; then compound 2; then compound 1.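

In this assay, the outer end of the chain carries much of the effect: taking away the ethyl gives a 10-fold higher number from compound 3 to compound 4 (1.00 log units; beyond the scatter), while the methyl in place of hydrogen that separates the two shorter chains gives a 2.5-fold lower number from compound 2 to compound 4 (0.40 log units; beyond the scatter). All four compounds keep one order, with no exception, the longer chain always giving the lower number, and the widest comparison through compound 4 gives a 20-fold lower number from compound 1 to compound 4 (1.30 log units; beyond the scatter). Nothing available explains why the chain end counts for so much.

From the compounds shown here alone, whether a still longer chain would lower the number further or reverse the trend remains open. So does the effect of a chain ending in a carboxylic acid or an amine.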